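Notes on the step to the pyrrolidine analogue

This account rests on a few compounds, and the source may have more. Where it says the series, first, only, none or still open, it means among the compounds named here.

Measured in a functional assay on MIA PaCa-2 cells (Homo sapiens) for inhibition, read by MTT assay, with a stated time of 48 h, tested at 10 uM; a lower number here means less inhibition of growth, a higher number more inhibition of growth at the concentration tested:
- compound 1 `Cc1cc(=O)c2c(O)cc(OC/C=C/c3ccccc3)c([C@H]3CCN(C)C[C@H]3O)c2o1`: 11%
- compound 2 `CCN(CC)Cc1c(O)c([C@H]2CCN(C)C[C@H]2O)c2oc(C)cc(=O)c2c1O`: 27%

Of the two measured compounds, compound 2 stands highest at 27%, and the gap down to compound 1 at 11% lies beyond the usual scatter. Growth inhibition is modest for both at the concentration tested.

The next entry is compound 3 `Cc1cc(=O)c2c(O)c(CN3CCCC3)c(O)c([C@H]3CCN(C)C[C@H]3O)c2o1`, which departs from compound 2 in one place: pyrrolidin-1-yl in place of diethylamino on a saturated chain carbon bound to an aromatic carbon. The open diethylamino group gives way to the pyrrolidin-1-yl ring, and the rest of the structure stays the same.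

Among the measured compounds shown here, no measured pair isolates this change, so the data offer no step to calibrate against. For the measured compounds named here, the only anchor is compound 2 at 27%. With so little to go on, no step beyond the scatter is expected in this assay, and any direction is tentative. The expected step of a number 3 percentage points higher from compound 2 to compound 3 (within the scatter) is an estimate with a wide margin. For compound 3 the estimated value is 30%, within an expected range of 12% to 50%.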

Compound 3, percent growth inhibition at one concentration: 28%
The estimate for compound 3 lay 2 percentage points above the measured number; low and high end bracket the measured number.
By their numbers in this assay, from the lowest: compound 1; then compounds 2 and 3 (each within the scatter of the next).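

Replacing the open diethylamino group with the pyrrolidin-1-yl ring, on a saturated chain carbon bound to an aromatic carbon, gives the first step read at this position in this assay: a number 1 percentage points higher from compound 2 to compound 3 (within the scatter). With the heavy-atom count and the hydrogen-bond donor and acceptor counts unchanged, tying the two ethyl arms into a ring leaves no readable difference in growth inhibition at the concentration tested, so this single pair gives no sign that the open or ring form of the amine matters here. Nothing at hand accounts for the two amines reading alike.

Still open, going by these compounds, is whether any other group at this place would separate from compound 2 and compound 3, such as dimethylamino, a piperidin-1-yl or morpholin-4-yl ring, or a longer chain carrying the amine. Also open, on these data alone, is whether compound 2 and compound 3 would stay this close at another concentration or on another cell line, since one pair at one concentration cannot settle how far the result extends.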